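Methyl to ethyl on the core: cytotoxicity expected unchanged

This account rests on a few compounds, and the source may have more. Where it says the series, first, only, none or still open, it means among the compounds named here.

Compound 1 `CCc1ccc2[nH]c(=O)c(CN(Cc3ccc(OC(F)F)cc3)Cc3ccc(C(C)(C)C)cc3)cc2c1` in a toxicity assay on MDCK cells (Canis lupus familiaris) for cytotoxicity, read by crystal violet staining, with a stated time of 48 h (on this read-out lower numbers stand for higher toxicity in this test and higher numbers for lower toxicity in this test), gives only a limit, > 5000 nM.
Compound 2 `CCc1ccc2[nH]c(=O)c(CN(Cc3ccc(C(C)(C)C)cc3)[C@H](CO)c3ccccc3)cc2c1` in this assay gives only a limit, > 10000 nM.
Compound 3 `Cc1ccc2[nH]c(=O)c(CN(Cc3ccc(C(C)(C)C)cc3)[C@@H](C)c3ccc(F)cc3)cc2c1` in this assay gives only a limit, > 5000 nM.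

Every number shown is a limit, so compound 3 cannot be placed against the others; it sits at the limit of > 5000 nM in this assay, at which 2 of the 3 values shown sit, while one value sits at the limit of > 10000 nM in this assay, at which 1 of the 3 values shown sits. Compound 4 `CCc1ccc2[nH]c(=O)c(CN(Cc3ccc(C(C)(C)C)cc3)[C@@H](C)c3ccc(F)cc3)cc2c1` differs from compound 3 by methyl in place of hydrogen on a saturated chain carbon bound to an aromatic carbon. Among the compounds with values here, the only measured step, a step that the two limits leave unreadable from compound 1 to compound 2, changes a different part of the molecule and is unreadable, so no measured step bears on this change. In this assay no step beyond the scatter is expected, giving a step that the limit leaves unreadable from compound 3 to compound 4. Compound 4 is therefore estimated at 8000 nM, with a range from 3000 nM to 25000 nM, most likely reported again as a limit.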

Compound 4, half-maximal cytotoxic concentration: > 5000 nM
Compound 4: only a limit was reported; the forecaster's own chance of this, stated with the estimate: 80%; the middle value lies beyond the limit too.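

Within the data shown here, compound 4 gives only a limit in this assay, as do compound 1, compound 2 and compound 3, so no step between them can be read. The compounds shown leave open where any true half-maximal cytotoxic concentration lies.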